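Trifluoromethoxy in Place of Hydrogen on the Aryl Ring

This account rests on a few compounds, and the source may have more. Where it says the series, first, only, none or still open, it means among the compounds named here.

Going by the values given here, compound 1 `C(=C/C1CCCCC1)\c1nc2cc(-c3ccccc3)ccc2[nH]1` stands at the higher of the two numbers measured so far; in a functional assay on HEK293 cells for antagonist activity at transient receptor potential M8 protein (Canis lupus familiaris), read by FLIPR and calcium flux (on this read-out lower numbers stand for stronger inhibition and higher numbers for weaker inhibition), compound 1 gives 110 nM. Compound 2 `Cc1ccccc1-c1ccc2[nH]c(/C=C/C3CCCCC3)nc2c1` gives 7.1 nM in this assay. Among the compounds with values here, the one step measured between them is a 15-fold lower number from compound 1 to compound 2 (1.19 log units; beyond the scatter). Compound 3 `FC(F)(F)Oc1ccccc1-c1ccc2[nH]c(/C=C/C3CCCCC3)nc2c1` changes compound 1 at the same place: trifluoromethoxy in place of hydrogen on an aromatic carbon. Within the data shown here, the methyl step is the only measured change that bears on this one, and it was large. Compound 3 is therefore expected to show a 7.3-fold lower number from compound 1 to compound 3 (0.87 log units; beyond the scatter) in this assay. For compound 3 the estimate is 15 nM, with a range from 4 nM to 60 nM.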

Compound 3, half-maximal inhibitory concentration: 14 nM
Compound 3: middle estimate off by 1.1-fold (0.03 log units), on the high side; the range from low to high includes it.
By their numbers in this assay, from the lowest: compounds 2 and 3 (each within the scatter of the next); then compound 1.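

Trifluoromethoxy on this aromatic carbon also brings a 7.9-fold lower number from compound 1 to compound 3 (0.90 log units; beyond the scatter) in this assay, so the drop seen with methyl is not tied to methyl alone. Replacing methyl with trifluoromethoxy gives a 2.0-fold higher number from compound 2 to compound 3 (0.29 log units; within the scatter), so this assay does not separate the two groups. Nothing available explains why either group has this effect.

On these data alone, whether the drop would survive with an amine, a carboxylic acid or a single fluorine at this place remains open. So does whether a longer chain such as ethoxy would be tolerated there.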